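The source may report more compounds than this note shows. Statements on the series, on what has been measured and on what is new or still open speak of the compounds shown alone.

Measured in a functional assay on the whole organism for agonist activity, with Mus musculus as the target; on this read-out higher numbers stand for an effect only at larger amounts of compound and lower numbers for an effect already at smaller amounts:
- compound 1 `CC(=O)N(C)C(C)C#CCn1ccnc1`: 2 mg/kg
- compound 2 `COC(=O)N(C)C(C)C#CCn1ccnc1`: 6.6 mg/kg
- compound 3 `CCOC(=O)N(C)CC#CCn1ccnc1`: > 100 mg/kg, a limit and not a number

As far as these compounds go, compound 3 sits at the limit of > 100 mg/kg in this assay, at which 1 of the 3 values shown sits, so its true position on the scale is unknown. Compound 4 `CCOC(=O)N(C)C(C)C#CCn1ccnc1` is compound 3 with a single change: methyl in place of hydrogen on a saturated chain carbon bound to an amide-type nitrogen and a triple-bonded carbon.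

Going by the values given here, no measured pair isolates this change. Among the compounds with values here, the only measured step, a 3.3-fold higher number from compound 1 to compound 2 (0.52 log units; beyond the scatter), comes from methoxy in place of methyl on a carbonyl carbon, so it bears on the new compound only indirectly. It does show that altering the group on the carbonyl can shift the number by a modest amount while the chain methyl stays in place.

Compound 1 and compound 2 both carry that chain methyl, and both give real numbers. Compound 2 gives 6.6 mg/kg, and this value anchors the expectation, with some allowance for a further modest rise. A clear step towards a lower number is therefore expected in this assay, though its size stays uncertain. The expected change is an at least 5.0-fold lower number from compound 3 to compound 4 (0.69 log units; beyond the scatter).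

For compound 4 the estimated value is 20 mg/kg, with an expected range from 7 mg/kg to 70 mg/kg.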

Compound 4, dose for half-maximal effect: > 100 mg/kg
Compound 4: no number, only a limit; the forecaster's own chance of this, stated with the estimate: 15%; middle value at least 5.0-fold (0.69 log units) away from the limit.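

In this assay compound 4 gives > 100 mg/kg, which is a limit and not a number, so methyl in place of hydrogen on this chain carbon does not bring an ethoxy compound into the measurable range. The step from compound 3 to compound 4 cannot be read, since both compounds stand at the same limit: the limit of > 100 mg/kg in this assay, at which 2 of the 4 values shown sit.

With the chain methyl present, the group on the carbonyl now appears to decide much more than the earlier modest step suggested, as ethoxy in place of methyl gives an at least 50-fold higher number from compound 1 to compound 4 (1.69 log units; beyond the scatter), and the one-carbon extension from methoxy to ethoxy gives an at least 15-fold higher number from compound 2 to compound 4 (1.18 log units; beyond the scatter).

As far as these compounds go, how far compound 3 and compound 4 lie beyond the end of the scale stays unknown, so any effect of the chain methyl on an ethoxy compound remains hidden. Also open, from the compounds shown here alone, are whether the chain methyl matters when the carbonyl carries methyl or methoxy, and where an amine on the carbonyl or an ethyl group in place of the chain methyl would fall.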